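The source may report more compounds than this note shows. Statements on the series, on what has been measured and on what is new or still open speak of the compounds shown alone.

Two compounds share a core and differ only in the group attached through an oxygen to the carbonyl of the ring nitrogen. Compound 1 `Cc1nc(S(C)(=O)=O)ccc1Oc1ncnc(OC2CCN(C(=O)OC3CCC3)CC2)c1F` carries a cyclobutyl there and in a functional assay on isolated protein for inhibition of Glucose-dependent insulinotropic receptor (Rattus norvegicus), read by HTRF and cAMP accumulation (on this read-out lower numbers stand for an effect already at smaller amounts and higher numbers for an effect only at larger amounts of compound), compound 1 gives 167 nM. Compound 2 `CCC1(OC(=O)N2CCC(Oc3ncnc(Oc4ccc(S(C)(=O)=O)nc4C)c3F)CC2)CC1` carries a 1-ethylcyclopropyl instead, and in this assay compound 2 gives 333 nM. Compound 2 stands as the higher of these two numbers, yet the gap is a 2.0-fold higher number from compound 1 to compound 2 (0.30 log units; within the scatter), so the two are not distinguishable. Compound 3 `Cc1nc(S(C)(=O)=O)ccc1Oc1ncnc(OC2CCN(C(=O)SC3CC3)CC2)c1F` changes the same position in a different way: a group of 4 heavy atoms (3 carbon, 1 sulfur; one three-membered non-aromatic ring of carbon only) in place of a group of 6 heavy atoms (5 carbon, 1 oxygen; one three-membered non-aromatic ring of carbon only), on a carbonyl carbon. Among the measured compounds shown here, no measured pair probes an exchange of oxygen for sulfur at this carbonyl; the only step available, from compound 1 to compound 2, shows that swapping one small ring for another here left the number within the scatter. On that basis compound 3 is expected to stay close to compound 2, and the estimated step of a 1.2-fold lower number from compound 2 to compound 3 (0.08 log units; within the scatter) is within the scatter. In this assay compound 3 is estimated at 280 nM, likely between 90 nM and 900 nM.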

Compound 3, half-maximal effective concentration: 126 nM
Compound 3: middle estimate off by 2.2-fold (0.35 log units), on the high side; measured number inside the range.
By their numbers in this assay, from the lowest: compounds 3, 1 and 2 (each within the scatter of the next, the first and the last beyond it).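

In this assay the step of a 1.3-fold lower number from compound 1 to compound 3 (0.12 log units; within the scatter) lies within the scatter, so compound 1 and compound 3 cannot be told apart, and a sulfur-linked group on this carbonyl carbon can match the oxygen-linked cyclobutyl group of compound 1. The step of a 2.6-fold lower number from compound 2 to compound 3 (0.42 log units; beyond the scatter) is modest but beyond the scatter, which shows what the first pair could not: changing the group at this position can shift the number measurably. Nothing available accounts for that shift.

As far as these compounds go, compound 3 differs from compound 1 and from compound 2 in two ways at once, the atom bound to the carbonyl carbon and the carbon group attached to that atom, so the part played by sulfur alone remains open, and a cyclopropyl group bound through oxygen would be the direct partner for separating the two. Also open, from the compounds shown here alone, is how this position would respond to a nitrogen link in place of oxygen or sulfur, or to an open chain such as isopropyl in place of a ring.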